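Swapping an aryl amide for a pyridine: clearance outlook

A few compounds are considered here, and "the series" means these few. Any claim that something is new, unique, unknown or untested is made for them only; others in the source may bear on it.

Measured so far:
compound 1 `CN1C[C@H](C(=O)Nc2ccc(C(F)(F)F)cc2)[C@@H](c2ccc(/C=C/C(=O)Nc3ccccc3N)cc2)C1` — 6 mL/min/kg
compound 2 `Cc1cc(NC(=O)[C@H]2CN(C)C[C@@H]2c2ccc(/C=C/C(=O)Nc3ccccc3N)cc2)ccc1Cl` — 15 mL/min/kg

In an in vitro ADME assay on microsomes from liver (Homo sapiens) for pharmacokinetics, read by LC-MS, with a stated time of 10 min, tested at 1 uM (on this read-out lower numbers stand for slow clearance and higher numbers for fast clearance), compound 1 gives the lowest number of the two, with compound 2 the nearest at a 2.5-fold higher number from compound 1 to compound 2 (0.40 log units; beyond the scatter). Compound 3 `CN1C[C@H](C(=O)Nc2ccccn2)[C@@H](c2ccc(/C=C/C(=O)Nc3ccccc3N)cc2)C1` differs from compound 1 by pyridin-2-yl in place of 4-(trifluoromethyl)phenyl on an amide-type nitrogen. Within the data shown here, no measured step covers this change; the only step seen, a 2.5-fold higher number from compound 1 to compound 2 (0.40 log units; beyond the scatter), concerns a different group on the same amide-type nitrogen and was modest. Compound 3 is therefore expected to stay near compound 1, with any step likely within or just beyond the scatter, giving an estimate of 8 mL/min/kg (range 4 mL/min/kg to 18 mL/min/kg), a step of a 1.3-fold higher number from compound 1 to compound 3 (0.12 log units; within the scatter).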

Compound 3, clearance: 8 mL/min/kg
Beside the measured number, compound 3's estimate shows no gap at the digits printed; the measured number falls inside the stated range.
By their numbers in this assay, from the lowest: compounds 1, 3 and 2 (each within the scatter of the next, the first and the last beyond it).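

In this assay the pyridin-2-yl amide gives a 1.3-fold higher number from compound 1 to compound 3 (0.12 log units; within the scatter) and a 1.9-fold lower number from compound 2 to compound 3 (0.27 log units; within the scatter) and so both steps stay within the scatter. The amide-type nitrogen therefore carries a smaller ring with one hetero atom, in place of either substituted phenyl, with no clear change in clearance. Nothing available explains this result. Still open, from the compounds shown here alone, is whether clearance stays in this range with a non-aromatic group, such as a piperidine ring, on that nitrogen. An amine or a carboxylic acid on the pyridin-2-yl ring is equally untested ground here.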